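The source may report more compounds than this note shows. Statements on the series, on what has been measured and on what is new or still open speak of the compounds shown alone.

Working notes on the series. In an ADME assay on MT2 cells (Homo sapiens) for cytotoxicity, read by MTT assay (on this read-out higher numbers stand for lower toxicity in this test and lower numbers for higher toxicity in this test), compound 1 `N#Cc1cc2c(Oc3ccc(F)cc3OCCn3ccc(=O)[nH]c3=O)cc(Cl)cn2c1` gives 15000 nM, and compound 3 `O=c1ccn(CCOc2ccccc2Oc2cc(Cl)cc3cc(Cl)ccc23)c(=O)[nH]1` gives 45000 nM. Going by the values given here, compound 2 `O=c1ccn(CCOc2ccccc2Oc2cccc3cc(Cl)ccc23)c(=O)[nH]1` reaches only the limit of this assay, > 100000 nM, so no number but a bound is known for it; it is the one value sitting at the limit of > 100000 nM in this assay, at which 1 of the 3 values shown sits. Compound 4 `O=c1ccn(CCOc2ccccc2Oc2cccc3ccccc23)c(=O)[nH]1` is yet to be measured; it differs from compound 2 by hydrogen in place of chloro on an aromatic carbon. Among the compounds with values here, the only measured step bearing on this change runs the opposite way: an at least 2.2-fold lower number from compound 2 to compound 3 (0.34 log units; beyond the scatter). Within the data shown here, removing the chloro is thus expected to leave compound 4 at or beyond the bound seen for compound 2, with no step toward higher toxicity. For compound 4 the expected value is 150000 nM (range 60000 nM to 400000 nM), an expected step that the limit leaves unreadable from compound 2 to compound 4, most likely again reported only as a limit.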

Compound 4, half-maximal cytotoxic concentration: 80000 nM
The estimate for compound 4 lay 1.9-fold (0.27 log units) above the measured number, and the stated range covers the measured number.
By their numbers in this assay, from the lowest: compound 1; then compounds 3 and 4 (each within the scatter of the next). At a limit, above all of these: compound 2.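

Replacing chloro with hydrogen on this aromatic carbon gives a number in this assay where the chloro compound gave none, and the change reads as an at least 1.2-fold lower number from compound 2 to compound 4 (0.09 log units; that floor lies within the scatter). From the compounds shown here alone, this shows no firm drop on losing the chloro, and the true size of the step stays unknown. The size cannot be read further because compound 2 carries only a limit: the limit of > 100000 nM in this assay, at which 1 of the 4 values shown sits.

Going by these compounds, whether a methoxy group, an amine or a carboxylic acid on this carbon would move the number beyond the scatter remains open.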